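A dimethylphenyl group replaces a nitrophenyl group

A few compounds are considered here, and "the series" means these few. Any claim that something is new, unique, unknown or untested is made for them only; others in the source may bear on it.

compound 1 `Cc1ccc(C(=O)Nc2cc(Cl)ccc2OCC(=O)Nc2ccc(S(N)(=O)=O)cc2C)cc1`: 54200 nM
compound 2 `Cc1cc(S(N)(=O)=O)ccc1NC(=O)COc1ccc(Cl)cc1NC(=O)c1cccc(F)c1`: 243000 nM
compound 3 `Cc1cc(S(N)(=O)=O)ccc1NC(=O)COc1ccc(Cl)cc1NC(=O)c1cccc([N+](=O)[O-])c1`: 58800 nM

In a functional assay on C8166 cells (Homo sapiens) for cytotoxicity, read by MTT assay (a lower number here means that less compound is tolerated, a higher number that more compound is tolerated), compound 3 stands close to compound 1, with a 1.1-fold higher number from compound 1 to compound 3 (0.04 log units; within the scatter), and apart from compound 2, with a 4.1-fold lower number from compound 2 to compound 3 (0.62 log units; beyond the scatter). The next compound, compound 4 `Cc1ccc(C)c(C(=O)Nc2cc(Cl)ccc2OCC(=O)Nc2ccc(S(N)(=O)=O)cc2C)c1`, carries 2,5-dimethylphenyl in place of 3-nitrophenyl on a carbonyl carbon. Two measured steps change the group at this place: a 1.1-fold higher number from compound 1 to compound 3 (0.04 log units; within the scatter), and a 4.5-fold higher number from compound 1 to compound 2 (0.65 log units; beyond the scatter). Compound 1, at 54200 nM, bears the measured group most like the entering one, so no step beyond the scatter is expected. The expected step is a 1.0-fold higher number from compound 3 to compound 4 (0.01 log units; within the scatter). For compound 4 the estimated value is 60000 nM, with an expected range of 25000 nM to 150000 nM.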

Compound 4, half-maximal cytotoxic concentration: 79700 nM
Beside the measured number, compound 4's estimate is 1.3-fold (0.12 log units) below it; the range from low to high includes it.
By their numbers in this assay, from the lowest: compounds 1, 3 and 4 (each within the scatter of the next); then compound 2.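

In this assay, the 2,5-dimethylphenyl group, which carries only carbon, falls in the same band as the 3-nitrophenyl and 4-methylphenyl groups, with a 1.4-fold higher number from compound 3 to compound 4 (0.13 log units; within the scatter) and a 1.5-fold higher number from compound 1 to compound 4 (0.17 log units; within the scatter). Compound 2 stays apart, with a 3.0-fold lower number from compound 2 to compound 4 (0.48 log units; beyond the scatter), so among these four compounds only the 3-fluorophenyl group separates from the others at this place. Nothing measured here accounts for that separation.

The compounds shown leave open whether an amine or a carboxylic acid on this carbonyl carbon, in place of the aromatic ring, would stay in that band or move towards compound 2.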